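This account rests on a few compounds, and the source may have more. Where it says the series, first, only, none or still open, it means among the compounds named here.

Measured so far:
- compound 1 `Cn1c(N)c(-c2nc3ccccc3[nH]2)c2nc(C#N)c(C#N)nc21`: > 50000 nM (a limit)
- compound 2 `CCn1c(N)c(-c2nc3ccccc3[nH]2)c2nc(C#N)c(C#N)nc21`: > 50000 nM (a limit)

In a functional assay on HeLa cells (Homo sapiens) for antiproliferative activity, read by MTT assay, with a stated time of 48 h (a lower number here means a stronger inhibitor, a higher number a weaker inhibitor), compound 2 gives > 50000 nM, which is a limit of the assay and not a number. It shares this position with compound 1, as the record shows: the limit of > 50000 nM in this assay, at which 2 of the 2 values shown sit. Within the data shown here, the only measured step is a step that the two limits leave unreadable from compound 1 to compound 2, so it offers no size to carry forward.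

Compound 3 `CN(C)CCn1c(N)c(-c2nc3ccccc3[nH]2)c2nc(C#N)c(C#N)nc21` extends the ethyl group of compound 2 to 2-(dimethylamino)ethyl. The change is dimethylamino in place of hydrogen on a saturated chain carbon, two bonds along the chain from an aromatic nitrogen, with dimethylamino in place of hydrogen on a saturated chain carbon, two bonds along the chain from an aromatic nitrogen. Among the measured compounds shown here, no measured pair contains this change, so the data give no direct guide to its effect.

A readable value is therefore possible, but another limit is about equally likely. The expected change, leaning only cautiously towards stronger inhibition, is an at least 2.0-fold lower number from compound 2 to compound 3 (0.30 log units; that floor lies within the scatter). For compound 3 the estimated value is 25000 nM, with an expected range from 4000 nM to 50000 nM.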

Compound 3, half-maximal inhibitory concentration: 8880 nM
Estimate against measurement, compound 3: 2.8-fold (0.45 log units) above, within the range that was stated.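

In this assay, compound 3 is the first compound with a substituted chain on this aromatic nitrogen to give a readable number instead of a limit: the limit of > 50000 nM in this assay, at which 2 of the 3 values shown sit.

Placing dimethylamino on the saturated chain carbon, two bonds along the chain from an aromatic nitrogen, gives an at least 5.6-fold lower number from compound 2 to compound 3 (0.75 log units; beyond the scatter), and measured against the shorter chain the change gives an at least 5.6-fold lower number from compound 1 to compound 3 (0.75 log units; beyond the scatter). Both sizes are floors, so the real steps may be larger, but they show that this position can respond to a change, which the step between compound 1 and compound 2 could not show, as that step cannot be read.

The compounds shown leave open whether the dimethylamino group itself matters or whether the longer chain alone would do the same, a question that a plain propyl chain or a chain ending in a hydroxyl group could help to separate. They also leave open whether a ring amine such as morpholine, or a longer chain carrying the same dimethylamino group, would move the number further.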